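Amide ring replacements in one series

This account rests on a few compounds, and the source may have more. Where it says the series, first, only, none or still open, it means among the compounds named here.

compound 1 `CC(C(=O)N1CCCCCC1)N1CCN(S(=O)(=O)c2ccc(C(C)(C)C)cc2)CC1`: > 40000 nM
compound 2 `CC1CCN(C(=O)C(C)N2CCN(S(=O)(=O)c3ccc(C(C)(C)C)cc3)CC2)CC1`: > 40000 nM

In an ADME assay on HepG2 cells (Homo sapiens) for inhibition, with a stated time of 48 h (on this read-out higher numbers stand for an effect only at larger amounts of compound and lower numbers for an effect already at smaller amounts), compound 1 gives only a limit, > 40000 nM. Compound 2 likewise reaches only a limit, > 40000 nM. For the measured compounds named here, the single measured step, a step that the two limits leave unreadable from compound 1 to compound 2, has no readable size because both values sit at the limit of > 40000 nM in this assay, at which 2 of the 2 values shown sit.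

Compound 3 `CC(C(=O)N1CCc2ccccc2C1)N1CCN(S(=O)(=O)c2ccc(C(C)(C)C)cc2)CC1` differs from compound 1 by 1,2,3,4-tetrahydroisoquinolin-2-yl in place of azepan-1-yl on a carbonyl carbon. Going by the values given here, the one measured step bears on a change at the same carbonyl carbon but is unreadable, so no direction can be taken from it. Compound 3 is expected to return a limit again, estimated at 50000 nM with a range of 15000 nM to 160000 nM. For compound 3 the expected step is a step that the limit leaves unreadable from compound 1 to compound 3.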

Compound 3, half-maximal effective concentration: 29000 nM
For compound 3 the middle estimate is 1.7-fold (0.24 log units) above the measured one; the measured number falls inside the stated range.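

Compound 3 is the only compound shown with a number rather than a limit in this assay, so this position on a carbonyl carbon can give a readable value with 1,2,3,4-tetrahydroisoquinolin-2-yl in place. The change gives an at least 1.3-fold lower number from compound 1 to compound 3 (0.13 log units; that floor lies within the scatter), and likewise an at least 1.3-fold lower number from compound 2 to compound 3 (0.13 log units; that floor lies within the scatter). These steps have only a floor because compound 1 and compound 2 each stand at a limit: the limit of > 40000 nM in this assay, at which 2 of the 3 values shown sit.

On these data alone, the true size of both steps stays open. So does whether morpholin-4-yl or an open-chain diethylamino group on the carbonyl carbon would also give a number.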